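This account rests on a few compounds, and the source may have more. Where it says the series, first, only, none or still open, it means among the compounds named here.

Compound 1 `Cn1c(Sc2ccc(C(=O)NO)cc2)nnc1-c1cccs1`: > 1000 nM
Compound 2 `Cn1c(Sc2c(F)cc(C(=O)NO)cc2F)nnc1-c1cccs1`: > 1000 nM
Compound 3 `O=C(NO)c1cc(F)c(Cc2nnc(-c3ccncc3)s2)c(F)c1`: > 1000 nM
Compound 4 `Cc1cc(-c2nnc(Sc3c(F)cc(C(=O)NO)cc3F)n2C)nn1C`: not yet measured

The three measured compounds were tested in an ADME assay on PBMC cells (Homo sapiens) for cytotoxicity, with a stated time of 72 h; a lower number here means a stronger inhibitor, a higher number a weaker inhibitor. In this assay, compound 2 gives > 1000 nM, which is a limit of the assay and not a number. The other two compounds are reported the same way, as the limit of > 1000 nM in this assay, at which 3 of the 3 values shown sit, shows. Among the compounds with values here, no measured compound therefore has an exact value, and no pair of measured compounds differing in one place shows the size of a step.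

Compound 4 differs from compound 2 in one place: 1,5-dimethyl-1H-pyrazol-3-yl in place of thiophen-2-yl on an aromatic carbon. In words, 1,5-dimethyl-1H-pyrazol-3-yl stands in place of thiophen-2-yl, on an aromatic carbon of a five-membered aromatic ring with 3 nitrogen.

With all three compounds at the same limit, no step beyond the scatter in this assay is expected in either direction. The expected step is a step that the limit leaves unreadable from compound 2 to compound 4, and this estimate rests only on the limit shown in the limit of > 1000 nM in this assay, at which 3 of the 3 values shown sit. For compound 4 the estimated value is 2000 nM, with an expected range from 1000 nM to 8000 nM.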

Compound 4, half-maximal inhibitory concentration: > 1000 nM
Compound 4 ended at the assay's limit (the forecaster's own chance of this, stated with the estimate: 85%); the middle value is on the limit's open side.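

In this assay compound 4 gives > 1000 nM, a limit of the assay and not a number. Compound 2 also sits at a limit, so no step can be read between compound 2 and compound 4. The compounds shown leave open whether 1,5-dimethyl-1H-pyrazol-3-yl in place of thiophen-2-yl changes the value at all.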